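Removing the Trifluoromethyl Group from the Aniline Ring

The source may hold more compounds than are shown below. What is called first, only, known or untested is meant among the compounds shown, and "the series" means these compounds.

Within the data shown here, compound 2 `COc1cc2ncnc(Nc3ccc(C(F)(F)F)cc3)c2cc1OCCCCC(=O)Nc1ccc(S(N)(=O)=O)cc1` gives 16900 nM in a functional assay on A-431 cells (Homo sapiens) for antiproliferative activity, read by MTT assay, with a stated time of 72 h (a higher number here means a weaker inhibitor, a lower number a stronger inhibitor), the lowest of the two numbers so far, though its gap to compound 1 is within the scatter. Compound 1 `COc1cc2ncnc(Nc3cccc(F)c3)c2cc1OCCCCC(=O)Nc1ccc(S(N)(=O)=O)cc1` gives 29900 nM. Compound 3 `COc1cc2ncnc(Nc3ccccc3)c2cc1OCCCCC(=O)Nc1ccc(S(N)(=O)=O)cc1` differs from compound 2 by hydrogen in place of trifluoromethyl on an aromatic carbon. Among the measured compounds shown here, the only step bearing on this change, which also alters the same aniline ring, is a 1.8-fold lower number from compound 1 to compound 2 (0.25 log units; within the scatter), within the scatter, so no shift beyond the scatter is expected in this assay. Compound 3 is therefore expected to give 22000 nM, between 8000 nM and 60000 nM, an expected step of a 1.3-fold higher number from compound 2 to compound 3 (0.11 log units; within the scatter).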

Compound 3, half-maximal inhibitory concentration: 25200 nM
For compound 3 the middle estimate is 1.1-fold (0.06 log units) below the measured one; low and high end bracket the measured number.
By their numbers in this assay, from the lowest: compounds 2, 3 and 1 (each within the scatter of the next).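

In this assay, hydrogen in place of trifluoromethyl gives a 1.5-fold higher number from compound 2 to compound 3 (0.17 log units; within the scatter) and hydrogen in place of fluoro gives a 1.2-fold lower number from compound 1 to compound 3 (0.07 log units; within the scatter), so the bare phenyl compound stands level with both substituted ones. Neither group, at the place it occupies on this ring, is thus shown to matter beyond the scatter. Nothing available here accounts for this.

As far as these compounds go, whether an amine or a carboxylic acid on the same ring would give a step beyond the scatter stays open. So does the effect of a longer chain in place of the one carrying the amide.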